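Swapping a pyridyl for a difluorophenyl on a fused core

This account rests on a few compounds, and the source may have more. Where it says the series, first, only, none or still open, it means among the compounds named here.

Compound 1 `C[C@H](Nc1ncnc2[nH]cnc12)c1nn(-c2ccncc2)c2cc(F)ccc12` and compound 2 `C[C@H](Nc1ncnc2[nH]cnc12)c1nn(-c2cccnc2)c2cc(Cl)ccc12` share a core and have both been tested in a functional assay on Bel-7402 cells (Homo sapiens) for inhibition, read by sulforhodamine B assay, with a stated time of 72 h, tested at 10 uM; on this read-out lower numbers stand for less inhibition and higher numbers for more inhibition at the one concentration tested (going by the name of the read-out). In this assay compound 1 gives 16%, and compound 2 gives 17%, the gap between them within the usual scatter, so neither can be set apart from the other. Among the compounds with values here, no single-point step between measured compounds is available here. Compound 3 `C[C@H](Nc1ncnc2[nH]cnc12)c1nn(-c2cc(F)cc(F)c2)c2cc(F)ccc12` has not been measured. It differs from compound 1 in one place: 3,5-difluorophenyl in place of pyridin-4-yl on an aromatic nitrogen. Within the data shown here, nothing among the measured compounds tells how a 3,5-difluorophenyl in place of pyridin-4-yl would shift the read-out, and the two numbers at hand sit close together near the low end. Compound 3 is therefore expected to land near compound 1, with an estimated step of a number 4 percentage points higher from compound 1 to compound 3 (within the scatter) that need not exceed the scatter. The estimate for compound 3 is 20%, within 5% to 45%.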

Compound 3, a percentage reported as inhibition, at one concentration (the size of the read-out at that concentration, not a potency): -8%
Beside the measured number, compound 3's estimate is 28 percentage points above it, and the stated range ends above it.
By their numbers in this assay, from the lowest: compound 3; then compounds 1 and 2 (each within the scatter of the next).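

Within the data shown here, on the aromatic nitrogen of the shared core, the choice of aryl group does register in this assay: 3,5-difluorophenyl in place of pyridin-4-yl gives a number 24 percentage points lower from compound 1 to compound 3 (beyond the scatter), the first change here that moves the read-out beyond the scatter. The swap takes out the ring nitrogen, with its one hydrogen-bond acceptor, and brings in two fluorine atoms, and compound 3 ends on a negative number, -8%. Nothing measured alongside these numbers says why the read-out moves.

Going by these compounds, it remains open whether the step follows the loss of the ring nitrogen or the arrival of the two fluorines. A plain phenyl or an aminophenyl on the same nitrogen could reveal which, and whether any group here gives inhibition well clear of compound 1 also stays unanswered.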